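This account rests on a few compounds, and the source may have more. Where it says the series, first, only, none or still open, it means among the compounds named here.

Two compounds of this series have a measured value in a functional assay on the whole organism (strain Swiss) with Mus musculus as the target, with a stated time of 0.25 h; on this read-out higher numbers stand for an effect only at larger amounts of compound and lower numbers for an effect already at smaller amounts. Compound 1 `CCC(C(=O)N1CCN(c2cccc(C(F)(F)F)c2)CC1)N1C(=O)CC(C)C1=O` gives 108 mg/kg, and compound 2 `CC1CC(=O)N(C(C)C(=O)N2CCN(c3cccc(Cl)c3)CC2)C1=O` gives 114 mg/kg; these two values lie within the usual scatter of each other. For compound 3 `CC(C(=O)N1CCN(c2cccc(C(F)(F)F)c2)CC1)N1C(=O)CC(C)(C)C1=O` the entry reads "not determined" (no result reported), so compound 3 stands without a number on this read-out. Compound 4 `CC1CC(=O)N(C(C)C(=O)N2CCN(c3cccc(C(F)(F)F)c3)CC2)C1=O` differs from compound 3 in one place: hydrogen in place of methyl on a saturated ring carbon. Within the data shown here, no measured pair shows this step, so its size is unknown; the expectation is a shift no larger than the scatter, in no preferred direction. Compound 4 shares part of its structure with compound 2, which gave 114 mg/kg, and another part with compound 1, which gave 108 mg/kg. Compound 4 is therefore expected to give about 110 mg/kg in this assay, within a range from 55 mg/kg to 220 mg/kg.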

Compound 4, dose for half-maximal effect: 65.7 mg/kg
Estimate against measurement, compound 4: 1.7-fold (0.22 log units) above, within the range that was stated.
By their numbers in this assay, from the lowest: compounds 4, 1 and 2 (each within the scatter of the next).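

In this assay, trifluoromethyl in place of chloro on the aromatic carbon gives a 1.7-fold lower number from compound 2 to compound 4 (0.24 log units; within the scatter), and hydrogen in place of methyl on the saturated chain carbon gives a 1.6-fold lower number from compound 1 to compound 4 (0.22 log units; within the scatter), so neither single change moves the read-out beyond the scatter. The step from 3,3-dimethyl-2,5-dioxopyrrolidin-1-yl to 3-methyl-2,5-dioxopyrrolidin-1-yl cannot be read, since compound 3 has no number. Nothing measured here explains these results.

Still open, on these data alone, is what a nitrile or methoxy group would do on that aromatic carbon. Also open, as far as these compounds go, is whether a longer chain on the saturated chain carbon would shift the read-out beyond the scatter.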